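A few compounds are considered here, and "the series" means these few. Any claim that something is new, unique, unknown or untested is made for them only; others in the source may bear on it.

Series notes. Going by the values given here, in an assay on isolated protein for inhibition of protein deacetylase HDAC6 (Homo sapiens), read by chemiluminescence, with a stated time of 3 h (on this read-out higher numbers stand for weaker inhibition and lower numbers for stronger inhibition), compound 1 `COc1ccc(NC(=O)CCCCCCNC(=O)C(O)(O)C(F)(F)F)cc1` gives 440000 nM, the highest number of the two measured so far. Compound 2 `COc1ccc2sc(NC(=O)CCCCCCNC(=O)C(O)(O)C(F)(F)F)nc2c1` gives 100000 nM in this assay, a lower number than compound 1, beyond the scatter. Compound 3 `O=C(CCCCCCNC(=O)C(O)(O)C(F)(F)F)Nc1ccc(-c2ccccc2)cc1` remains to be measured in this assay. It differs from compound 1 as follows: phenyl in place of methoxy on an aromatic carbon. Among the compounds with values here, no step of this kind has been measured, so the expectation rests only on compound 2 showing that a change at this end of the chain can lower the number. A modest step toward stronger inhibition is expected, a 2.9-fold lower number from compound 1 to compound 3 (0.47 log units; beyond the scatter). Compound 3 is estimated at 150000 nM in this assay, between 40000 nM and 600000 nM.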

Compound 3, half-maximal inhibitory concentration: 38000 nM
Estimate against measurement, compound 3: 3.9-fold (0.60 log units) above; measured number below the stated range.
By their numbers in this assay, from the lowest: compound 3; then compound 2; then compound 1.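

In this assay, going by these compounds alone, the aromatic carbon para to a large group proves sensitive to what it carries: phenyl in place of methoxy gives a 12-fold lower number from compound 1 to compound 3 (1.06 log units; beyond the scatter) as the first single-place step. A six-membered aromatic ring of carbon only is thus accepted at this place, and the number falls despite the larger group. No measurement at hand accounts for this step.
As far as these compounds go, whether the aromatic ring itself matters remains open, since a cyclohexyl group at this place would be needed to separate ring type from size. From the compounds shown here alone, an amine or a carboxylic acid on the far ring of compound 3 is equally open.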